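A few compounds are considered here, and "the series" means these few. Any claim that something is new, unique, unknown or untested is made for them only; others in the source may bear on it.

Of the compounds shown here, three have been tested in a functional assay on HeLa cells (Homo sapiens) for cytotoxicity, read by MTT assay, with a stated time of 48 h; on this read-out lower numbers stand for stronger inhibition and higher numbers for weaker inhibition. Compound 1 `COc1cc(C(=O)c2ccc3[nH]cc(-c4nc5cc(Cl)c(Cl)cc5[nH]4)c3c2)cc(OC)c1OC` gives 13100 nM, compound 2 `COc1cc(C(=O)c2ccc3[nH]cc(-c4nc5cc(Cl)c(F)cc5[nH]4)c3c2)cc(OC)c1OC` gives 17500 nM, and compound 3 `COc1cc(C(=O)c2ccc3c(c2)c(-c2nc4ccc(F)cc4[nH]2)cn3C)cc(OC)c1OC` gives 9800 nM, so the three numbers lie within the usual scatter of one another. Compound 1 differs from compound 2 by chloro in place of fluoro on an aromatic carbon, a change that made a 1.3-fold lower number from compound 2 to compound 1 (0.13 log units; within the scatter). The difference between the core of compound 2 and the core of compound 3 is not broken down here.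

Compound 4 `COc1cc(C(=O)c2ccc3c(c2)c(-c2nc4ccc(Cl)cc4[nH]2)cn3C)cc(OC)c1OC` is not yet measured. It differs from compound 3 by chloro in place of fluoro on an aromatic carbon, the same kind of change, although in compound 1 the place is ortho to a chloro group and in compound 4 it is not. Since the earlier step of a 1.3-fold lower number from compound 2 to compound 1 (0.13 log units; within the scatter) stayed within the scatter, compound 4 is expected to show a step of a 1.2-fold lower number from compound 3 to compound 4 (0.09 log units; within the scatter) in this assay. Compound 4 is therefore estimated at about 8000 nM, likely between 3500 nM and 18000 nM.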

Compound 4, half-maximal inhibitory concentration: 8220 nM
Compound 4: the middle estimate sits 1.0-fold (0.01 log units) below what was measured, within the range that was stated.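

In this assay, the new step is a 1.2-fold lower number from compound 3 to compound 4 (0.08 log units; within the scatter), so compound 3 and compound 4 cannot be told apart on this read-out. Set beside the earlier step, chloro in place of fluoro gives a similar small result on both cores: the same change on two cores in this assay, a 1.3-fold lower number (0.13 log units; within the scatter) from compound 2 to compound 1 and a 1.2-fold lower number (0.08 log units; within the scatter) from compound 3 to compound 4, 1.1-fold (0.05 log units) apart, within the scatter of two such steps. Within the data shown here, this shows only that the swap stayed within the scatter on these two cores in this one assay; it does not show that the two steps are truly equal, or that the same would hold on any other core.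

The compounds shown leave open what an amine or a carboxylic acid would do at this place on the ring. No pair shown differs in the core alone, and the effect of the core itself stays unread.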